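Hydroxy for Chloro on the Pendant Aromatic Ring

A few compounds are considered here, and "the series" means these few. Any claim that something is new, unique, unknown or untested is made for them only; others in the source may bear on it.

Of the compounds shown here, two built on one shared core have been measured in a functional assay on the whole organism (strain Wistar albino) for inhibition, with Rattus norvegicus as the target, read by paw edema, with stated times of 30 min and 3 h, at a dose of 0.05 mmol/kg; on this read-out higher numbers stand for more inhibition at the one dose given (going by the name of the read-out) and lower numbers for less inhibition. Compound 1 `Cc1ccc([C@@H]2CC(c3cccc(O)c3)=NN2c2ccc(S(N)(=O)=O)cc2)cc1` gives 64.7% in this assay. Compound 2 `NS(=O)(=O)c1ccc(N2N=C(c3cccc(O)c3)C[C@H]2c2ccccc2Cl)cc1` gives 32.6% in this assay, the lowest of the two numbers; its nearest measured relative is compound 1, and the step of a number 32.1 percentage points lower from compound 1 to compound 2 (beyond the scatter) came with 2-chlorophenyl in place of 4-methylphenyl on a saturated ring carbon. Compound 3 `NS(=O)(=O)c1ccc(N2N=C(c3cccc(O)c3)C[C@H]2c2ccccc2O)cc1` has not been measured. It differs from compound 2 by hydroxy in place of chloro on an aromatic carbon, the exchange sitting on an aromatic carbon of a six-membered aromatic ring of carbon only. Going by the values given here, no measured step bears directly on this change: the one known step, a number 32.1 percentage points lower from compound 1 to compound 2 (beyond the scatter), exchanged a whole aryl group for another at a saturated ring carbon and says nothing about swapping a single substituent within that aryl group. With no guidance from the data, the step of a number 5.4 percentage points higher from compound 2 to compound 3 (within the scatter) is expected to stay within the scatter, although the range must be wide. The estimate for compound 3 is 38%, from 18% to 62%.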

Compound 3, a percentage reported as inhibition, in the whole organism at one dose (the size of the read-out at that dose, not a potency): 35.4%
For compound 3 the middle estimate is 2.6 percentage points above the measured one, within the range that was stated.
By their numbers in this assay, from the lowest: compounds 2 and 3 (each within the scatter of the next); then compound 1.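

In this assay, hydroxy in place of chloro on an aromatic carbon, ortho to a large group, changes the number only within the scatter (a number 2.8 percentage points higher from compound 2 to compound 3 (within the scatter)), so this read-out does not separate the two substituents, although hydroxy adds a hydrogen-bond donor and a hydrogen-bond acceptor that chloro lacks. Compound 3 also remains clearly short of compound 1 (a number 29.3 percentage points lower from compound 1 to compound 3 (beyond the scatter)), which shows that the gap first seen with 2-chlorophenyl is still there with 2-hydroxyphenyl. Nothing measured here explains either result.

The steps from compound 1 change both the substituent and its place on the ring, so the compounds shown cannot tell whether the gap follows the place of the substituent or the methyl group of 4-methylphenyl. They also leave open whether an amine or a methoxy group on the same aromatic carbon would stay level with chloro and hydroxy or move the number beyond the scatter.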